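This account rests on a few compounds, and the source may have more. Where it says the series, first, only, none or still open, it means among the compounds named here.

Measured compounds:
compound 1, `ClCc1ccccc1Cn1cnc2c(Cl)ncnc21`, 44700 nM
compound 2, `ClCc1ccccc1Cn1cnc2ncnc(Cl)c21`, 60300 nM

The account concerns two measured compounds and one that awaits measurement. In a functional assay on NCI-H460 cells (Homo sapiens) for cytotoxicity, read by sulforhodamine B assay, with a stated time of 48 h (a lower number here means a stronger inhibitor of growth, a higher number a weaker inhibitor of growth), compound 1 gives 44700 nM. In this assay compound 2 gives 60300 nM, the higher of the two numbers, but the gap to compound 1 lies within the scatter of this kind of measurement, so the two compounds cannot be set in order on these numbers alone.

Compound 3, `ClCc1ccccc1Cn1cnc2nc(Cl)nc(Cl)c21`, is the next compound, obtained from compound 2 by the change (chloro in place of hydrogen on an aromatic carbon). Among the measured compounds shown here, no pair among the measured compounds shows what this change does, so the size of the step is unknown. Adding a chloro group where a hydrogen stood is a small alteration of the shared core, and the two measured compounds, which differ in a larger rearrangement of that core, sit close together in this assay. A step of modest size is therefore expected, more likely toward a lower number than a higher one, yet not clearly beyond the scatter.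

Compound 3 is estimated to give 40000 nM in this assay, within a range from 15000 nM to 110000 nM, which corresponds to an expected step of a 1.5-fold lower number from compound 2 to compound 3 (0.18 log units; within the scatter).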

Compound 3, concentration for total growth inhibition: 5880 nM
Estimate against measurement, compound 3: 6.8-fold (0.83 log units) above; measured number below the stated range.
By their numbers in this assay, from the lowest: compound 3; then compounds 1 and 2 (each within the scatter of the next).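

In this assay, chloro in place of hydrogen on this aromatic carbon, which lies between two ring nitrogen atoms, gives a 10-fold lower number from compound 2 to compound 3 (1.01 log units; beyond the scatter), a large step that lies beyond the scatter. Among the compounds shown here, compound 1 and compound 2 could not be set in order and offered no pair with this change; this step is the first sign that the position responds strongly to the addition of a single chlorine atom, on a six-membered aromatic ring with 2 nitrogen that already carries a chloro group. No measurement shown here explains the size of this step.

Going by these compounds, it remains open whether the lower number belongs to chloro itself or would also follow from another group on this carbon, such as an amine, a methoxy group or a fluoro group. On these data alone, it is equally open whether the same change would produce a step of similar size on the core of compound 1, since a single pair shows this change and it cannot establish a general pattern.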